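Cinnamamide to dimethoxy-cinnamamide on a shared naphthol core

The source may report more compounds than this note shows. Statements on the series, on what has been measured and on what is new or still open speak of the compounds shown alone.

Measured compounds: compound 1 `O=C(/C=C/c1ccc([N+](=O)[O-])cc1)Nc1cc(Sc2ncn[nH]2)c(O)c2ccccc12` with > 100000 nM; compound 2 `O=C(Nc1cc(Sc2ncn[nH]2)c(O)c2ccccc12)c1ccc2ccccc2c1` with 45100 nM.

In a functional assay on MDA-MB-231 cells (Homo sapiens) for antiproliferative activity, read by MTT assay, with a stated time of 48 h (a lower number here means a stronger inhibitor, a higher number a weaker inhibitor), compound 1 gives only a limit, > 100000 nM, and so stands at the limit of > 100000 nM in this assay, at which 1 of the 2 values shown sits. In this assay compound 2 gives 45100 nM. Compound 3 `COc1ccc(/C=C/C(=O)Nc2cc(Sc3ncn[nH]3)c(O)c3ccccc23)cc1OC` is not yet measured; it carries 3,4-dimethoxyphenyl in place of 4-nitrophenyl on a double-bonded chain carbon bound to a double-bonded chain carbon. Among the measured compounds shown here, with no measured step between the two cinnamamides, the move is expected to be no larger than the scatter, perhaps a modest gain, so the step from compound 1 to compound 3 is estimated at an at least 1.4-fold lower number from compound 1 to compound 3 (0.15 log units; that floor lies within the scatter). Compound 3 is therefore expected to give about 70000 nM, between 25000 nM and 200000 nM.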

Compound 3, half-maximal inhibitory concentration: 52500 nM
The estimate for compound 3 lay 1.3-fold (0.12 log units) above the measured number, and the stated range covers the measured number.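

In this assay, 3,4-dimethoxyphenyl in place of 4-nitrophenyl on this double-bonded chain carbon gives an at least 1.9-fold lower number from compound 1 to compound 3 (0.27 log units; that floor lies within the scatter). For compound 1, > 100000 nM is a limit of the assay and not a number. The step is therefore only a floor, and its full size cannot be read: the limit of > 100000 nM in this assay, at which 1 of the 3 values shown sits.

The compounds shown leave open whether a single methoxy group would serve as well as the pair in 3,4-dimethoxyphenyl. They also leave open how an amine or a carboxylic acid on the phenyl ring at this place would read.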